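The compounds below may be only part of what the source reports. "The series", "measured", "known", "first", "only" and "open" are said of these compounds alone.

The series shares one core, shown by compound 1 `O=C(Nc1ccc2nc(Nc3ccc(Cl)c(Cl)c3)c(Nc3ccc(Cl)c(Cl)c3)nc2c1)c1cccc(C(F)(F)F)c1`, compound 2 `Nc1ccc2nc(Nc3ccc(Cl)c(Cl)c3)c(Nc3ccc(Cl)c(Cl)c3)nc2c1` and compound 3 `O=C(Nc1ccc2nc(Nc3ccc(Cl)c(Cl)c3)c(Nc3ccc(Cl)c(Cl)c3)nc2c1)C1CCCCC1`, and differs only in what sits on the amine of compound 2. In a toxicity assay on HepG2 cells (Homo sapiens) for cytotoxicity, read by MTT assay, with a stated time of 24 h (on this read-out higher numbers stand for lower toxicity in this test and lower numbers for higher toxicity in this test), compound 2 gives 25100 nM. For compound 1 this assay returns "nd" (no result reported), and for compound 3 it likewise returns "nd" (no result reported), so compound 3 stands without a number of its own, and the only figure available for the whole core comes from compound 2.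

Compound 4 `CC(=O)Nc1ccc2nc(Nc3ccc(Cl)c(Cl)c3)c(Nc3ccc(Cl)c(Cl)c3)nc2c1` is the next member. The change from compound 3 to compound 4 is methyl in place of cyclohexyl on a carbonyl carbon. For the measured compounds named here, no measured pair in this set shows what such a change does in this assay, so the size and direction of the step cannot be read from the data; with the single number for compound 2 as the only anchor, no shift beyond the usual scatter is assumed in either direction.

Compound 4 is therefore expected to fall near 25000 nM in this assay, within a range from 8000 nM to 80000 nM.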

Compound 4, half-maximal cytotoxic concentration: 8600 nM
The estimate for compound 4 lay 2.9-fold (0.46 log units) above the measured number, and the stated range covers the measured number.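

Acetyl in place of hydrogen on the aromatic nitrogen gives the first readable step in this series: in this assay, the number falls a 2.9-fold lower number from compound 2 to compound 4 (0.47 log units; beyond the scatter). The step is modest but beyond the scatter, so this position is not silent, and here acylation of the amine goes with higher toxicity in this test. No measurement at hand explains the shift.

The steps to compound 1 and compound 3 cannot be read, which leaves open whether cyclohexylcarbonyl or the trifluoromethyl-bearing benzoyl group would follow acetyl, or whether the shift is particular to acetyl. Also open, on these data alone, is what a longer acyl chain such as butanoyl, a plain methyl on that nitrogen, or a sulfonamide would do at this position.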